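Replacing iodo with an aryl group on compound 3

The source may report more compounds than this note shows. Statements on the series, on what has been measured and on what is new or still open speak of the compounds shown alone.

Compound 3 `O=C(CCc1cccc2c1B(O)OC2)Nc1cccc(I)c1` gives 630 nM in a functional assay on SK-OV-3 cells (Homo sapiens) for antiproliferative activity, read by MTT assay, with a stated time of 72 h (on this read-out higher numbers stand for weaker inhibition and lower numbers for stronger inhibition), the lowest of the three numbers shown, though its gap to compound 2 `Cc1ccc(NC(=O)CCc2cccc3c2B(O)OC3)cc1` at 860 nM lies within the scatter. Compound 1 `O=C(CCc1cccc2c1B(O)OC2)Nc1ccc(I)cc1` gives 51000 nM. Compound 4 `O=C(CCc1cccc2c1B(O)OC2)Nc1cccc(-c2cccc(C(F)(F)F)c2)c1` differs from compound 3 by 3-(trifluoromethyl)phenyl in place of iodo on an aromatic carbon. For the measured compounds named here, no measured step replaces iodo with a ring: the nearest precedent is a 59-fold lower number from compound 1 to compound 2 (1.77 log units; beyond the scatter), a swap of one group for another on an aromatic carbon, while an 81-fold lower number from compound 1 to compound 3 (1.91 log units; beyond the scatter) moves the iodo rather than replacing it. Neither shows how a 3-(trifluoromethyl)phenyl will behave, so for compound 4 only a modest step of uncertain direction is expected, a 1.6-fold higher number from compound 3 to compound 4 (0.20 log units; within the scatter). Compound 4 is therefore estimated at 1000 nM, within 200 nM to 6000 nM.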

Compound 4, half-maximal inhibitory concentration: 390 nM
Beside the measured number, compound 4's estimate is 2.6-fold (0.41 log units) above it; the measured number falls inside the stated range.
By their numbers in this assay, from the lowest: compounds 4, 3 and 2 (each within the scatter of the next, the first and the last beyond it); then compound 1.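

Putting 3-(trifluoromethyl)phenyl in place of iodo on this aromatic carbon brings in a whole aromatic ring where a single iodine atom stood, yet this assay shows only a 1.6-fold lower number from compound 3 to compound 4 (0.21 log units; within the scatter). In this one example, then, the position accepts a far larger group with no change beyond the scatter. Nothing available explains this result. On these data alone, it remains open whether a phenyl ring carrying an amine or a carboxylic acid would fare the same here. Also open, as far as these compounds go, is what the same aryl group would do in place of the iodo of compound 1.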